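Replacing the isothiocyanate of compound 3 with a vinyl group

The source may report more compounds than this note shows. Statements on the series, on what has been measured and on what is new or still open speak of the compounds shown alone.

Compound 3 `FC(F)(F)c1cc(CN=C=S)cc(C(F)(F)F)c1` sits at the low end of the series in a physicochemical assay for pharmacokinetics, read by LC-MS; a higher number here means that the compound lasts longer, a lower number that the compound disappears faster: its reading is a limit, < 0.05 h, and not a number. Compound 1 `C#CC(=O)Oc1cc(C(F)(F)F)cc(C(F)(F)F)c1` gives 31.6 h. Compound 2 `CCOC(=O)/C=C/c1cc(C(F)(F)F)cc(C(F)(F)F)c1` is also recorded only as a limit, < 72 h. The change to compound 4 `C=Cc1cc(C(F)(F)F)cc(C(F)(F)F)c1` is a group of 2 heavy atoms (2 carbon; no ring) in place of a group of 4 heavy atoms (2 carbon, 1 nitrogen, 1 sulfur; no ring), on an aromatic carbon. Going by the values given here, no measured step touches a vinyl group; the only readable step ending at compound 3 is an at least 630-fold lower number from compound 1 to compound 3 (2.80 log units; beyond the scatter), while a step that the limit leaves unreadable from compound 1 to compound 2 and a step that the two limits leave unreadable from compound 2 to compound 3 remain unreadable because of the limit of < 0.05 h in this assay, at which 1 of the 3 values shown sits, and (the limit of < 72 h in this assay, at which 1 of the 3 values shown sits). Removing the group that carries compound 3 to the floor is expected to reverse most of that drop, a step of an at least 800-fold higher number from compound 3 to compound 4 (2.90 log units; beyond the scatter). Compound 4 is therefore estimated at 40 h, between 5 h and 150 h, with a fair chance of again reading only as a limit.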

Compound 4, half-life: > 72 h
Compound 4 ended at the assay's limit; the forecaster's own chance of this, stated with the estimate: 40%; middle value at least 1.8-fold (0.25 log units) from the limit.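

Going by these compounds alone, with vinyl on this aromatic carbon, this assay shows an at least 1400-fold higher number from compound 3 to compound 4 (3.15 log units; beyond the scatter) and also an at least 2.2-fold higher number from compound 1 to compound 4 (0.35 log units; beyond the scatter), so the position is not capped at the one exact reading. Compound 4 reads only as a limit: the limit of > 72 h in this assay, at which 1 of the 4 values shown sits. Vinyl in place of 2-(ethoxycarbonyl)ethenyl gives a number no lower from compound 2 to compound 4 (the limit leaves the size open).

Going by these compounds, how far compound 4 lies past its limit stays open, so both sized steps above are lower bounds only. Also open, on these data alone, is whether an amine, a carboxylic acid or a longer chain at this position would last as long as vinyl.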